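Amide and sulfonamide variants at the ring nitrogen

The compounds below may be only part of what the source reports. "The series", "measured", "known", "first", "only" and "open" are said of these compounds alone.

Compound 1 `COc1ccc(-c2cn3cc(C4=CCN(S(=O)(=O)CCc5ccccc5)CC4)ccc3n2)cc1OC` gives 70300 nM in an ADME assay on HEK293 cells (Homo sapiens) for cytotoxicity, read by MTT assay, with a stated time of 48 h; on this read-out lower numbers stand for stronger inhibition and higher numbers for weaker inhibition.
Compound 2 `COc1ccc(-c2cn3cc(C4=CCN(C(=O)c5ccccc5C(F)(F)F)CC4)ccc3n2)cc1OC` gives 82900 nM in this assay.

Among the compounds with values here, compound 2 carries the highest of the two numbers measured so far; its nearest neighbour is compound 1, and the step of a 1.2-fold higher number from compound 1 to compound 2 (0.07 log units; within the scatter) lies within the scatter, so the two compounds cannot be ordered on these data. The change from phenethylsulfonyl to (2-(trifluoromethyl)phenyl)carbonyl on the amine nitrogen in the ring thus left the read-out essentially unchanged.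

Compound 3 `COc1ccc(-c2cn3cc(C4=CCN(C(=O)C5CCCCC5)CC4)ccc3n2)cc1OC` is the next variant, not yet measured. It differs from compound 2 by cyclohexyl in place of 2-(trifluoromethyl)phenyl on a carbonyl carbon, the difference reading one bond further out as (2-(trifluoromethyl)phenyl)carbonyl to cyclohexylcarbonyl. Within the data shown here, the only step on record that touches this position is the one from compound 1 to compound 2, and it stayed within the scatter. Among the measured compounds shown here, no step compares an aromatic with a non-aromatic ring on the carbonyl carbon, so the expectation rests on the flat behaviour seen so far: no shift beyond the scatter in this assay is expected, with a 1.1-fold lower number from compound 2 to compound 3 (0.04 log units; within the scatter) as the estimated step.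

Compound 3 is therefore expected to give about 75000 nM in this assay, within a range from 35000 nM to 160000 nM.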

Compound 3, half-maximal inhibitory concentration: 72100 nM
Estimate against measurement, compound 3: 1.0-fold (0.02 log units) above, within the range that was stated.
By their numbers in this assay, from the lowest: compounds 1, 3 and 2 (each within the scatter of the next).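

On the carbonyl carbon, cyclohexyl in place of 2-(trifluoromethyl)phenyl gives a 1.1-fold lower number from compound 2 to compound 3 (0.06 log units; within the scatter) in this assay, so this first comparison of an aromatic with a non-aromatic ring at this place, which also removes the three fluorine atoms and goes from 10 heavy atoms to 6, produces no shift beyond the scatter. Cyclohexylcarbonyl in place of phenethylsulfonyl on the amine nitrogen in the ring gives a 1.0-fold higher number from compound 1 to compound 3 (0.01 log units; within the scatter), so an amide without an aromatic ring on its carbonyl carbon also cannot be told apart from the sulfonamide in this read-out. No measurement accompanies these values that could account for this flat behaviour across the three compounds.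

Each of the three groups on the ring nitrogen carries a six-membered carbon ring, so the compounds shown leave open whether an open chain such as acetyl, or a group bearing an amine or a carboxylic acid on the carbonyl carbon, would stay within the scatter of these numbers. They also leave open whether the same flat response holds once the dimethoxyphenyl group on the shared core is replaced, for instance by an unsubstituted phenyl.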